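The compounds below may be only part of what the source reports. "The series", "measured", "known", "first", "only" and "open" are said of these compounds alone.

Compound 1 `Nc1cc(N)c2nc(-c3ccccc3)c(NCc3ccc(Cl)c(Cl)c3)nc2c1` — in a functional assay on OVCAR-4 cells (Homo sapiens) for inhibition, read by sulforhodamine B assay, with a stated time of 48 h (a higher number here means a weaker inhibitor of growth, a lower number a stronger inhibitor of growth), compound 1 gives < 100000 nM, a limit of the assay rather than a number.
Compound 2 `Nc1cc(N)c2nc(-c3ccccc3)c(Sc3ccc(F)cc3)nc2c1` — compound 2 gives 56200 nM.
Compound 3 `Nc1cc(N)c2nc(-c3ccccc3)c(Sc3ccc(Cl)c(Cl)c3)nc2c1` — compound 3 gives < 100000 nM, again a limit of the assay.

Compound 1 therefore stands only at a limit in this assay, and of the three values shown, two sit at that same limit (the limit of < 100000 nM in this assay, at which 2 of the 3 values shown sit). The unmeasured compound 4 `COc1ccc(CNc2nc3cc(N)cc(N)c3nc2-c2ccccc2)cc1` differs from compound 1 in one place: 4-methoxyphenyl in place of 3,4-dichlorophenyl on a saturated chain carbon bound to a nitrogen on an aromatic ring.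

Among the measured compounds shown here, the single one-place step among the measured compounds, a step that the limit leaves unreadable from compound 2 to compound 3, is made unreadable by the limit, and it concerns a change on a sulfur rather than on the saturated chain carbon that carries the change from compound 1 to compound 4. For the measured compounds named here, no measured step bears directly on the 4-methoxyphenyl for 3,4-dichlorophenyl exchange, so no direction can be read from the data; the only anchor is that compound 1 sits at a limit, and the one number recorded, for compound 2, lies in the same weak region.

Compound 4 is therefore expected to give about 60000 nM in this assay, between 20000 nM and 100000 nM, an estimated step that the limit leaves unreadable from compound 1 to compound 4, with a fair chance that only a limit is returned.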

Compound 4, concentration for total growth inhibition: 21400 nM
Estimate against measurement, compound 4: 2.8-fold (0.45 log units) above; the measured number falls inside the stated range.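

The exchange of 3,4-dichlorobenzyl for 4-methoxybenzyl that links compound 1 and compound 4 gives no readable step in this assay, because compound 1 stands only at a limit of the assay: the limit of < 100000 nM in this assay, at which 2 of the 4 values shown sit. The compounds shown leave open how large that exchange is, and even in which direction it acts on growth inhibition.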